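A few compounds are considered here, and "the series" means these few. Any claim that something is new, unique, unknown or untested is made for them only; others in the source may bear on it.

Of the compounds shown here, two on the shared core have been measured so far. In a functional assay on MKN-45 cells (Homo sapiens) for antiproliferative activity, read by MTT assay, with a stated time of 72 h (a higher number here means a weaker inhibitor, a lower number a stronger inhibitor), compound 1 `COc1cc(CCc2ccccc2Cl)cc(OC)c1O` gives 24500 nM, a weak reading. Compound 2 `COc1cc(CCc2ccc(Cl)cc2)cc(OC)c1O` reads > 25000 nM in this assay, and this value is a limit of the assay, not a number. Among the compounds with values here, no exact position for compound 2 can therefore be given, and no measured step between compounds that differ in one place is available as a guide.

Compound 3 `COc1cc(CCc2ccc(Cl)cc2Cl)cc(OC)c1O` differs from compound 2 by chloro in place of hydrogen on an aromatic carbon, ortho to a large group and meta to a chloro group.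

Within the data shown here, compound 1, at 24500 nM, is the only numerical reading, so the expectation in this assay is for a small step towards a stronger inhibitor rather than a large one. The expected change is an at least 1.3-fold lower number from compound 2 to compound 3 (0.14 log units; that floor lies within the scatter), and this estimate is uncertain in size. A reading that is again only a limit would not be surprising. For compound 3 the expected value is 18000 nM, with an estimated range of 7000 nM to 30000 nM.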

Compound 3, half-maximal inhibitory concentration: 4460 nM
Beside the measured number, compound 3's estimate is 4.0-fold (0.61 log units) above it, and the stated range ends above it.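

In this assay, chloro in place of hydrogen on an aromatic carbon, ortho to a large group and meta to a chloro group, gives an at least 5.6-fold lower number from compound 2 to compound 3 (0.74 log units; beyond the scatter). Starting from the other single-chloro compound, chloro in place of hydrogen on an aromatic carbon gives a 5.5-fold lower number from compound 1 to compound 3 (0.74 log units; beyond the scatter), so on the shared core the compound with two chloro groups reads beyond the scatter of compound 1 and clear of the limit of compound 2. The first of these steps is a floor and not a full size, because compound 2 stands at a limit of the assay and not at a number: the limit of > 25000 nM in this assay, at which 1 of the 3 values shown sits.

As far as these compounds go, it remains open whether fluoro, bromo or methyl at this position would give a step of similar size, and so whether the step belongs to chloro itself or to any group placed there. Also open, from the compounds shown here alone, is whether the lower number of compound 3 would hold with an amine or a carboxylic acid in place of the hydroxyl group on the shared core, or with a longer chain joining the two aromatic parts.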